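The source may report more compounds than this note shows. Statements on the series, on what has been measured and on what is new or still open speak of the compounds shown alone.

Measured so far in an ADME assay on Vero cells (Chlorocebus sabaeus) for cytotoxicity, read by MTT assay, with a stated time of 48 h; on this read-out higher numbers stand for weaker inhibition and lower numbers for stronger inhibition:

- Compound 1 `O=c1cc(N2CCN(CC3CCC(NS(=O)(=O)c4ccccc4)CC3)CC2)sc2c([N+](=O)[O-])cc(C(F)(F)F)cc12`: > 64 ug/mL
- Compound 2 `Cc1ccc(C(=O)OC2CCC(CN3CCN(c4cc(=O)c5cc(C(F)(F)F)cc([N+](=O)[O-])c5s4)CC3)CC2)cc1`: > 64 ug/mL
- Compound 3 `C=CC(=O)OC1CCC(CN2CCN(c3cc(=O)c4cc(C(F)(F)F)cc([N+](=O)[O-])c4s3)CC2)CC1`: > 64 ug/mL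

Compound 3 stands at > 64 ug/mL, and this is a limit of the assay and not a number. The same holds for the other two compounds, so the series offers only (the limit of > 64 ug/mL in this assay, at which 3 of the 3 values shown sit).

Compound 4 `O=C(OC1CCC(CN2CCN(c3cc(=O)c4cc(C(F)(F)F)cc([N+](=O)[O-])c4s3)CC2)CC1)c1cccc(F)c1` keeps the shared core and the ester of compound 3, but 3-fluorophenyl comes in place of vinyl on a carbonyl carbon: 3-fluorophenyl in place of vinyl on a carbonyl carbon.

The closest measured change is at this same carbonyl carbon, where vinyl replaces 4-methylphenyl, and it is a step that the two limits leave unreadable from compound 2 to compound 3. The changes on the saturated ring carbon are a step that the two limits leave unreadable from compound 1 to compound 2 and a step that the two limits leave unreadable from compound 1 to compound 3. None of these gives a size, so none gives a direction either. With all three compounds at the limit in this assay, no step beyond the scatter is expected, and another limit is the likeliest report for compound 4. The expected change is a step that the limit leaves unreadable from compound 3 to compound 4, and this is an estimate only. For compound 4 the estimated value is 80 ug/mL, with an expected range from 35 ug/mL to 160 ug/mL.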

Compound 4, half-maximal inhibitory concentration: > 64 ug/mL
Compound 4 was reported as a limit; the forecaster's own chance of this, stated with the estimate: 85%; the middle value does not contradict the limit.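

In this assay compound 4 gives > 64 ug/mL, which is a limit of the assay and not a number. No step can be read between compound 4 and compound 1, compound 2 or compound 3: the limit of > 64 ug/mL in this assay, at which 4 of the 4 values shown sit. The compounds shown leave open where each of the four truly stands in this assay, and whether any change on the carbonyl carbon or the saturated ring carbon shifts the value.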